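The source may hold more compounds than are shown below. What is called first, only, known or untested is meant among the compounds shown, and "the series" means these compounds.

In a functional assay on MCF7 cells (Homo sapiens) for antiproliferative activity, read by MTT assay, with a stated time of 48 h (a higher number here means a weaker inhibitor, a lower number a stronger inhibitor), compound 1 `FC(F)(F)c1ccc2[nH]c(-c3cn(-c4ccccc4)nc3-c3ccccc3)nc2c1` gives 2660 nM, compound 2 `Fc1ccc(-c2nn(-c3ccccc3)cc2-c2nc3ccccc3[nH]2)cc1` gives 3200 nM and compound 3 `Fc1ccc(-c2nn(-c3ccccc3)cc2-c2nc3cc(Cl)ccc3[nH]2)cc1` gives 2230 nM, which places compound 3 within the scatter of both others. Compound 4 `Fc1ccc(-c2nn(-c3ccccc3)cc2-c2nc3cc(C(F)(F)F)ccc3[nH]2)cc1` differs from compound 3 in one place: trifluoromethyl in place of chloro on an aromatic carbon. Among the measured compounds shown here, the one measured step that bears on this, a 1.4-fold lower number from compound 2 to compound 3 (0.16 log units; within the scatter), stayed within the scatter, although it is a different swap. Compound 1 also carries trifluoromethyl, and its 2660 nM is close to the value of compound 3, though the two differ elsewhere too. No step beyond the scatter is therefore expected in this assay, and the estimated step is a 1.1-fold higher number from compound 3 to compound 4 (0.05 log units; within the scatter). For compound 4 the expected value is 2500 nM, with an estimated range of 1300 nM to 4800 nM.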

Compound 4, half-maximal inhibitory concentration: 2130 nM
Estimate against measurement, compound 4: 1.2-fold (0.07 log units) above; low and high end bracket the measured number.
By their numbers in this assay, from the lowest: compounds 4, 3, 1 and 2 (each within the scatter of the next).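

In this assay trifluoromethyl and chloro at this position cannot be told apart (a 1.0-fold lower number from compound 3 to compound 4 (0.02 log units; within the scatter)). Trifluoromethyl in place of hydrogen here also leaves the number within the scatter (a 1.5-fold lower number from compound 2 to compound 4 (0.18 log units; within the scatter)), and so does the addition of fluoro elsewhere in the molecule (a 1.2-fold lower number from compound 1 to compound 4 (0.10 log units; within the scatter)). No supporting measurement is available to explain these small steps. Going by these compounds, whether an amine or a carboxylic acid at this position would move the number beyond the scatter remains open.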